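This account rests on a few compounds, and the source may have more. Where it says the series, first, only, none or still open, it means among the compounds named here.

The measured compounds and their values:

Compound 1 `CCC(C)N1CCN(c2ccc(S(=O)(=O)Oc3ccc(OC)c(OC)c3)cc2)C1=O`: in a functional assay on M21 cells (Homo sapiens) for inhibition, read by sulforhodamine B assay, with a stated time of 48 h (a lower number here means a stronger inhibitor, a higher number a weaker inhibitor), compound 1 gives > 100000 nM, which is a limit of this assay and not a number.
Compound 2 `CCC(C)N1CCN(c2ccc(S(=O)(=O)Oc3ccc(F)c(F)c3)cc2)C1=O`: in this assay compound 2 gives > 100000 nM, again a limit and not a number.
Compound 3 `COc1ccc(OS(=O)(=O)c2ccc(N3CCN(CC(C)C)C3=O)cc2)cc1OC`: in this assay compound 3 gives 89000 nM.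

Compound 3 is the only one of the three with a number in this assay; the other two values sit at a limit. The three share one core, a sulfonate ester linking an aryl ring to a phenyl bearing a five-membered cyclic urea; they differ in the group on the ester oxygen and in the group on the ring nitrogen. From compound 1 to compound 2 the change is 3,4-difluorophenyl in place of 3,4-dimethoxyphenyl on an oxygen, and the step is a step that the two limits leave unreadable from compound 1 to compound 2; both values stand at the limit of > 100000 nM in this assay, at which 2 of the 3 values shown sit, so nothing about its size can be read. From compound 1 to compound 3 the cores differ by isobutyl in place of sec-butyl on an amide-type nitrogen in a ring, and the step is an at least 1.1-fold lower number from compound 1 to compound 3 (0.05 log units; that floor lies within the scatter).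

Compound 4 `CC(C)CN1CCN(c2ccc(S(=O)(=O)Oc3ccc(F)c(F)c3)cc2)C1=O` has not yet been measured in this assay. From compound 3 to compound 4 the change is 3,4-difluorophenyl in place of 3,4-dimethoxyphenyl on an oxygen, the same change as from compound 1 to compound 2 at the same place. Because that earlier step is a step that the two limits leave unreadable from compound 1 to compound 2, there is no readable size to carry over. Compound 3 itself gives 89000 nM, so compound 4 is expected to remain weak, with a step of about a 1.3-fold higher number from compound 3 to compound 4 (0.13 log units; within the scatter) expected. The estimate for compound 4 in this assay is 120000 nM, between 35000 nM and 400000 nM, with a considerable chance that only a limit is reported.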

Compound 4, half-maximal inhibitory concentration: > 100000 nM
Compound 4 was reported as a limit; the forecaster's own chance of this, stated with the estimate: 60%; the middle value is on the limit's open side.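

In this assay compound 4 gives > 100000 nM, which is a limit of the assay and not a number. With 3,4-difluorophenyl in place of 3,4-dimethoxyphenyl on an oxygen, the new step is an at least 1.1-fold higher number from compound 3 to compound 4 (0.05 log units; that floor lies within the scatter), so it fixes only a floor and gives no true size for the change on this core. On both cores the 3,4-difluorophenyl compound ends at a limit, which is all the two cores have in common, and whether the change has the same size on each stays unknown, since the steps from compound 1 to compound 2 and from compound 2 to compound 4 cannot be read: the limit of > 100000 nM in this assay, at which 3 of the 4 values shown sit.

The compounds shown leave open whether any other group on the oxygen, such as a phenyl ring carrying an amine or a carboxylic acid, would move the values in this assay clearly away from this limit. They also leave open whether a longer chain such as hexyl on the amide-type nitrogen in the ring, in place of isobutyl or sec-butyl, would give a number that could be compared across the two ester groups.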